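Methoxy for fluoro in the weaker member of the pair

This account rests on a few compounds, and the source may have more. Where it says the series, first, only, none or still open, it means among the compounds named here.

The series shares one core and is read in a functional assay on HT-29 cells (Homo sapiens) for cytotoxicity, read by MTT assay, with a stated time of 72 h; a lower number here means a stronger inhibitor, a higher number a weaker inhibitor. Compound 1 `O=C(Nc1nc2ccc(Cl)cc2s1)c1cn(-c2ccccc2)nc1-c1ccc(F)cc1` gives 3320 nM and compound 2 `Cc1ccc2nc(NC(=O)c3cn(-c4ccccc4)nc3-c3ccc(F)cc3)sc2c1` gives 22900 nM; the step of a 6.9-fold higher number from compound 1 to compound 2 (0.84 log units; beyond the scatter) came with methyl in place of chloro on an aromatic carbon. Compound 2 thus stands with the higher of the two numbers and is the weaker of the pair in this assay. Compound 3 `COc1ccc(-c2nn(-c3ccccc3)cc2C(=O)Nc2nc3ccc(C)cc3s2)cc1` differs from compound 2 by methoxy in place of fluoro on an aromatic carbon. Going by the values given here, no measured step touches this exchange: the one step seen, a 6.9-fold higher number from compound 1 to compound 2 (0.84 log units; beyond the scatter), concerns a different group and says nothing about fluoro against methoxy. Among the compounds with values here, with no precedent, the expected step of a 1.1-fold higher number from compound 2 to compound 3 (0.04 log units; within the scatter) is none beyond the scatter, in either direction, and the range is set wide accordingly. Compound 3 is therefore expected to give 25000 nM, between 6000 nM and 100000 nM.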

Compound 3, half-maximal inhibitory concentration: 21500 nM
Compound 3: the middle estimate sits 1.2-fold (0.07 log units) above what was measured; the range from low to high includes it.
By their numbers in this assay, from the lowest: compound 1; then compounds 3 and 2 (each within the scatter of the next).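

In this assay, going from 4-fluorophenyl to 4-methoxyphenyl gives a 1.1-fold lower number from compound 2 to compound 3 (0.03 log units; within the scatter), so on this aromatic carbon, para to a large group, the read-out does not separate fluoro from methoxy, even though methoxy alone is counted with a hydrogen-bond acceptor. Going by these compounds alone, the only step beyond the scatter so far, a 6.9-fold higher number from compound 1 to compound 2 (0.84 log units; beyond the scatter), lies at the chloro and methyl place on the other side of the amide, so this is the first reading at the aryl place, and it holds for the methyl compounds only. No supporting measurement bears on why the two groups read alike.

On these data alone, whether the same exchange reads alike in the chloro compound stays open. Also open, as far as these compounds go, is whether an amine, a carboxylic acid or a longer chain such as butoxy at this place would move the number beyond the scatter.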